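The compounds below may be only part of what the source reports. "The series", "measured", "known", "first", "only" and "open" are said of these compounds alone.

Compound 1 `Fc1ccc(-c2csc(N/N=C/c3ccc(Cl)cc3Cl)n2)cc1`: 93.3%
Compound 2 `Fc1ccc(-c2csc(N/N=C/c3cccs3)n2)cc1`: 93.3%
Compound 3 `Cc1ccc(-c2csc(N/N=C/c3cccs3)n2)cc1`: 97%

In a functional assay, read by spectrophotometry, with a stated time of 15 min, tested at 40 ug/mL (on this read-out lower numbers stand for a weaker effect and higher numbers for a stronger effect at the one concentration tested), compound 1 gives 93.3%, and compound 2 gives 93.3%, so at the digits printed the two stand level. Compound 3 gives 97%, a number that also lies within the usual scatter of compound 1, so none of the three can be set apart from the others on these readings.

Compound 4 `COc1ccc(-c2csc(N/N=C/c3ccc(Cl)cc3Cl)n2)cc1` differs from compound 1 in one place: methoxy in place of fluoro on an aromatic carbon. Among the compounds with values here, the only measured step that touches this kind of change is the one from compound 2 to compound 3, where a methyl replaces a fluoro on an aromatic carbon, and that step was a number 3.7 percentage points higher from compound 2 to compound 3 (within the scatter), within the scatter. A new group taking the place of the fluoro on that carbon therefore left this assay essentially unchanged the one time it was tried, though only methyl was tried, not methoxy, and the other end of the molecule differed from that of compound 1.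

On that basis the step to compound 4 is expected to be a number 0.3 percentage points lower from compound 1 to compound 4 (within the scatter), no change beyond the scatter. Compound 4 is estimated at 93%, between 84% and 99%.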

Compound 4, a percentage reported as inhibition, at one concentration (the size of the read-out at that concentration, not a potency): 69.5%
Compound 4: the middle estimate sits 23.5 percentage points above what was measured; measured number below the stated range.
By their numbers in this assay, from the lowest: compound 4; then compounds 1, 2 and 3 (each within the scatter of the next).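

In this assay, swapping 4-fluorophenyl for 4-methoxyphenyl gives a number 23.8 percentage points lower from compound 1 to compound 4 (beyond the scatter) and so shows that this carbon, para to a large group, is not indifferent to what it carries. The earlier step of methyl in place of fluoro, a number 3.7 percentage points higher from compound 2 to compound 3 (within the scatter), had given no sign of this, so a replacement here can leave the read-out in place in one pair of compounds and lower it in another. Nothing available on these compounds accounts for the lower number.

The two steps differ both in the group that enters and in the far end of the molecule, so the compounds shown leave open whether methoxy itself matters or whether it lowers the number only alongside the far end of compound 1, a question that methoxy on the far end of compound 2 would address. Also open, as far as these compounds go, is how the read-out would respond to other groups on the same carbon, such as a hydroxyl, an amine or the longer ethoxy chain, and whether the size of the step follows from the group that enters.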